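Hydrazone aryl swap on the shared core: chlorophenyl to hydroxyphenyl

The compounds below may be only part of what the source reports. "The series", "measured", "known", "first", "only" and "open" are said of these compounds alone.

Among the measured compounds shown here, compound 2 `CN(C)CCn1cnnc1-c1cc(Oc2ccc(NC(=O)N/N=C/c3ccc(Cl)cc3)cc2F)ccn1` gives 1370 nM in a functional assay on U-87MG ATCC cells (Homo sapiens) for cytotoxicity, read by MTT assay, with a stated time of 72 h (a lower number here means a stronger inhibitor, a higher number a weaker inhibitor), the highest of the two numbers so far; the nearest is compound 1 `CN(C)CCn1cnnc1-c1cc(Oc2ccc(NC(=O)N/N=C/c3c(O)ccc4ccccc34)cc2F)ccn1`, which in this assay gives 620 nM. Compound 3 `CN(C)CCn1cnnc1-c1cc(Oc2ccc(NC(=O)N/N=C/c3cccc(O)c3)cc2F)ccn1` differs from compound 2 by 3-hydroxyphenyl in place of 4-chlorophenyl on a carbon with a double bond to nitrogen. For the measured compounds named here, the only step that bears on it is a 2.2-fold higher number from compound 1 to compound 2 (0.34 log units; beyond the scatter), where a hydroxyl-bearing aryl left and the chlorophenyl entered. A hydroxyl-bearing aryl now returns, so a modest move toward a lower number is expected, a 1.5-fold lower number from compound 2 to compound 3 (0.18 log units; within the scatter). Compound 3 is estimated at 900 nM, between 400 nM and 2500 nM.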

Compound 3, half-maximal inhibitory concentration: > 100000 nM
Compound 3: a limit, no number; the forecaster's own chance of this, stated with the estimate: 3%; middle value at least 110-fold (2.04 log units) from the limit.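

Compound 3 gives a limit, not a number, in this assay: the limit of > 100000 nM in this assay, at which 1 of the 3 values shown sits. At this carbon with a double bond to nitrogen, the swap to 3-hydroxyphenyl brings an at least 72-fold higher number from compound 2 to compound 3 (1.86 log units; beyond the scatter), and the comparison with the other hydroxyl-bearing aryl gives an at least 160-fold higher number from compound 1 to compound 3 (2.20 log units; beyond the scatter), both far larger than a 2.2-fold higher number from compound 1 to compound 2 (0.34 log units; beyond the scatter). A hydroxyl on the aryl therefore does not by itself go with the lower number, since compound 1 and compound 3 both carry one and still stand far apart.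

The compounds shown leave open whether the step follows the hydroxyl itself or its place on the ring. A 3-chlorophenyl or 4-hydroxyphenyl group on the same carbon would separate the two.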